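A few compounds are considered here, and "the series" means these few. Any claim that something is new, unique, unknown or untested is made for them only; others in the source may bear on it.

Measured so far in an assay on cells (Epithelial cell) with Cystic fibrosis transmembrane conductance regulator variant F508del (Homo sapiens) as the target, read by fluorescence, with a stated time of 20 h; a higher number here means a weaker inhibitor, a lower number a stronger inhibitor:
Compound 1, `COc1ccc(Cl)cc1Nc1nc2c(s1)CCCCc1nc(N)sc1-2`, gives 9200 nM.
Compound 2, `COc1ccc(Cl)cc1Nc1nc2c(s1)CCCCc1nc(NC(=O)C3CC3)sc1-2`, gives 4500 nM.

Compound 2 holds the lowest of the two numbers. Among the compounds with values here, its nearest neighbour is compound 1, and that gap is a 2.0-fold lower number from compound 1 to compound 2 (0.31 log units; beyond the scatter), the only measured step, brought about by cyclopropylcarbonyl in place of hydrogen on a nitrogen on an aromatic ring.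

Compound 3, `CCC(C)C(=O)Nc1nc2c(s1)-c1nc(Nc3cc(Cl)ccc3OC)sc1CCCC2`, has not been measured in this assay. It differs from compound 2 by sec-butyl in place of cyclopropyl on a carbonyl carbon. Within the data shown here, no measured step exchanges one acyl group for another; the step from compound 1 to compound 2 only shows that adding the cyclopropylcarbonyl group lowered the number modestly, so it bears on this change just in showing that the acyl position tolerates substitution. The expectation is that trading cyclopropyl for sec-butyl on the carbonyl carbon gives a change no larger than the scatter, with a 1.1-fold lower number from compound 2 to compound 3 (0.05 log units; within the scatter) taken as the expected step. Compound 3 is therefore estimated at 4000 nM, with a range from 1800 nM to 9000 nM.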

Compound 3, half-maximal inhibitory concentration: 2900 nM
For compound 3 the middle estimate is 1.4-fold (0.14 log units) above the measured one; the range from low to high includes it.
By their numbers in this assay, from the lowest: compounds 3 and 2 (each within the scatter of the next); then compound 1.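

In this assay, within the data shown here, the exchange of cyclopropyl for sec-butyl on the carbonyl carbon is the first direct comparison of one acyl group with another at this amide, and it reads as a 1.6-fold lower number from compound 2 to compound 3 (0.19 log units; within the scatter) with no separation of the two compounds beyond the usual scatter. The three-membered ring of the cyclopropyl group is therefore not required at this position for compound 3 to match compound 2, as the open, branched sec-butyl group serves within the scatter. The earlier result is also no longer tied to a single acyl group, since the second one gives a 3.2-fold lower number from compound 1 to compound 3 (0.50 log units; beyond the scatter) and so, like the cyclopropylcarbonyl group, stands beyond the scatter from the free amino compound.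

Nothing available explains these numbers. Open still is how this position responds to an acyl group carrying an amine or a carboxylic acid, or to a longer straight chain, and whether any such group would separate from compound 2 by more than the scatter.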